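The source may report more compounds than this note shows. Statements on the series, on what has been measured and on what is new or still open speak of the compounds shown alone.

Compound 2 `CNC(=O)[C@H]1O[C@@H](n2cnc3c(NOC)nc(C#Cc4ccc(F)cc4)nc32)[C@H](O)[C@@H]1O` was tested in an assay on CHO cells for agonist activity at adenosine receptor A3 (Homo sapiens), read by fluorescence, with stated times of 15 min and 45 min (on this read-out lower numbers stand for an effect already at smaller amounts and higher numbers for an effect only at larger amounts of compound), and gave 210 nM. For the measured compounds named here, the only other compound measured, compound 1 `CNC(=O)[C@H]1O[C@@H](n2cnc3c(NC)nc(C#Cc4ccc(F)cc4)nc32)[C@H](O)[C@@H]1O`, gave 190 nM in this assay, and the step of a 1.1-fold higher number from compound 1 to compound 2 (0.04 log units; within the scatter) places the two side by side rather than apart. Compound 3 `CNC(=O)[C@H]1O[C@@H](n2cnc3c(NOC)nc(C#Cc4ccc(OC)cc4)nc32)[C@H](O)[C@@H]1O` has not yet been measured. It differs from compound 2 in a single place: methoxy in place of fluoro on an aromatic carbon. Going by the values given here, no measured step touches this ring; the one step available concerns the group on a nitrogen of the shared core and lay within the scatter, so there is no direct guide for the present exchange. Absent such a guide, the expected step from compound 2 to compound 3 in this assay is a 1.2-fold higher number from compound 2 to compound 3 (0.09 log units; within the scatter), that is, nothing clearly beyond the scatter. Compound 3 is therefore estimated at 260 nM in this assay, with a range from 80 nM to 850 nM.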

Compound 3, half-maximal effective concentration: 112 nM
Compound 3: the middle estimate sits 2.3-fold (0.37 log units) above what was measured, and the stated range covers the measured number.
By their numbers in this assay, from the lowest: compounds 3, 1 and 2 (each within the scatter of the next).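

For the compounds shown here, this is the first measured exchange on the outer aromatic ring: at this position, para to a large group, methoxy in place of fluoro gives a 1.9-fold lower number from compound 2 to compound 3 (0.27 log units; within the scatter) in this assay. The ring position therefore takes a methoxy, with its oxygen and extra carbon, where a lone fluorine stood, and the read-out does not clearly separate compound 2 from compound 3. No separate measurement is available to explain this result.

Still open, as far as these compounds go, is whether groups of a different kind at this position, such as an amine, a carboxylic acid or a longer chain, would also stay within the scatter. Also open, from the compounds shown here alone, is whether 4-methoxyphenyl in place of 4-fluorophenyl would give a similar step with methyl rather than methoxy on the nitrogen of the shared core.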